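Ester chain change from compound 3 to compound 4

This account rests on a few compounds, and the source may have more. Where it says the series, first, only, none or still open, it means among the compounds named here.

Compound 3 `COC(=O)C1=C(C)NC(C)=C(C(=O)OCC(F)(F)F)C1c1cccc([N+](=O)[O-])c1` gives 16 nM in a functional assay on HEK293 cells for antagonist activity at Voltage-dependent L-type calcium channel subunit alpha-1C (Oryctolagus cuniculus), read by FLIPR (on this read-out higher numbers stand for weaker inhibition and lower numbers for stronger inhibition), the lowest of the three numbers shown; compound 1 `CCCCC1=C(C(=O)OCC)C(c2cccc([N+](=O)[O-])c2)C(C(=O)OCC)=C(C)N1` gives 20 nM, within the scatter of compound 3, while compound 2 `CCOC(=O)C1=C(C)NC(COC(=O)c2ccccc2)=C(C(=O)OCC)C1c1cccc([N+](=O)[O-])c1` gives 210 nM, beyond it. Compound 4 `COC(=O)C1=C(C)NC(C)=C(C(=O)OCCCCc2ccccc2)C1c1cccc([N+](=O)[O-])c1` differs from compound 3 by 3-phenylpropyl in place of trifluoromethyl on a saturated chain carbon bound to an oxygen next to a carbonyl group. For the measured compounds named here, the only measured step, an 11-fold higher number from compound 1 to compound 2 (1.02 log units; beyond the scatter), sits on a saturated chain carbon bound to a double-bonded ring carbon, not on a saturated chain carbon bound to an oxygen next to a carbonyl group, so no measured step bears directly on the present change. Lacking any guide in the numbers, a step of modest size in either direction, possibly within the scatter, is expected: a 1.9-fold higher number from compound 3 to compound 4 (0.27 log units; within the scatter). Compound 4 is estimated at 30 nM, within the range 8 nM to 120 nM.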

Compound 4, half-maximal inhibitory concentration: 10 nM
For compound 4 the middle estimate is 3.0-fold (0.48 log units) above the measured one; the measured number falls inside the stated range.
By their numbers in this assay, from the lowest: compounds 4, 3 and 1 (each within the scatter of the next); then compound 2.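

On a saturated chain carbon bound to an oxygen next to a carbonyl group, 3-phenylpropyl in place of trifluoromethyl gives a 1.6-fold lower number from compound 3 to compound 4 (0.20 log units; within the scatter) in this assay and so brings no step beyond the scatter. This ester chain therefore accepts the entering group, with its nine heavy atoms and six-membered aromatic ring, with no measurable loss on this read-out. Nothing shown explains this result. 

From the compounds shown here alone, what an amine or a carboxylic acid at the end of this chain would give remains open. So does the outcome for a shorter or longer phenylalkyl chain.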